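This account rests on a few compounds, and the source may have more. Where it says the series, first, only, none or still open, it means among the compounds named here.

Compound 3 `CC[C@H](C)[C@H](N)CN(C(=O)[C@@H]1C[C@H]1c1cccnc1)c1ccc(-c2ccccc2)cc1` stands at the high end of the two single numbers in a functional assay for agonist activity at G protein-coupled receptor 88 (Homo sapiens), read by HTRF and cAMP accumulation; a lower number here means that less compound is needed, a higher number that more compound is needed for the effect: compound 3 gives 1500 nM. Among the compounds with values here, its nearest neighbour is compound 2 `CC[C@H](C)[C@H](N)CN(C(=O)[C@@H]1C[C@H]1c1ccccc1F)c1ccc(-c2ccccc2)cc1`, which gives 650 nM in this assay, and the step of a 2.3-fold higher number from compound 2 to compound 3 (0.36 log units; beyond the scatter) is the only measured change on the saturated ring carbon. Compound 1 `CC[C@H](C)[C@H](N)CN(C(=O)[C@@H]1C[C@H]1c1ccccc1)c1ccc(-c2ccccc2)cc1` has two entries in this assay, 230 nM; 800 nM (2 entries), and the spread between them the several entries of compound 1 in this assay, 230 nM; 800 nM (2 entries) shows how far repeats of one compound can lie apart. Compound 4 `CC[C@H](C)[C@H](N)CN(C(=O)[C@@H]1C[C@H]1c1cccs1)c1ccc(-c2ccccc2)cc1` is not yet measured. It differs from compound 3 by thiophen-2-yl in place of pyridin-3-yl on a saturated ring carbon. The step that bears on this is the one from 2-fluorophenyl to pyridin-3-yl, which was modest and beyond the scatter; the present exchange removes the pyridin-3-yl again, so the number for compound 4 is expected to move back toward those of compound 2 and compound 1, that is a modest decrease a 3.0-fold lower number from compound 3 to compound 4 (0.48 log units; beyond the scatter). Compound 4 is therefore estimated at 500 nM, with a range from 150 nM to 1700 nM.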

Compound 4, half-maximal effective concentration: 360 nM
Beside the measured number, compound 4's estimate is 1.4-fold (0.14 log units) above it; measured number inside the range.
By their numbers in this assay, from the lowest: compounds 4 and 2 (each within the scatter of the next); then compound 3.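

In this assay a five-membered aromatic ring with sulfur is accepted on this saturated ring carbon, and the exchange for pyridin-3-yl gives a clear step (a 4.2-fold lower number from compound 3 to compound 4 (0.62 log units; beyond the scatter)). Thiophen-2-yl and 2-fluorophenyl cannot be told apart here (a 1.8-fold lower number from compound 2 to compound 4 (0.26 log units; within the scatter)), so among the compounds with single numbers only compound 3, with pyridin-3-yl, stands apart from the others. Compound 1, with an unsubstituted phenyl, gives no firm third reference, as its repeats lie far apart: the several entries of compound 1 in this assay, 230 nM; 800 nM (2 entries).

Ring size and hetero atom change together from compound 3 to compound 4, so it remains open which of the two carries the step. Also open, going by these compounds, is how a non-aromatic group at this carbon, such as an open alkyl chain or a primary amine, would behave.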